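The source may hold more compounds than are shown below. What is called first, only, known or untested is meant among the compounds shown, and "the series" means these compounds.

For the measured compounds named here, in a functional assay on A2780 cells (Homo sapiens) for antiproliferative activity, read by MTT assay, with a stated time of 48 h (a higher number here means a weaker inhibitor, a lower number a stronger inhibitor), only two compounds have numbers so far. Compound 1 `CCNCC(=O)Nc1cc(OC)ccc1C(=O)c1ccc(OC)c2c1C=CC(C)(C)O2` gives 4090 nM, and compound 2 `C=C(c1ccc(OC)cc1NC(=O)CN)c1ccc(OC)c2c1OC(C)(C)C=C2` gives 80 nM. Compound 2 therefore holds the lower of the two numbers, and the gap is well beyond the usual scatter of repeated measurements. The two structures differ in more than one place, so this gap cannot be pinned on any single change.

The next compound is compound 3 `C=C(c1ccc(OC)cc1NC(=O)CNCC)c1ccc(OC)c2c1OC(C)(C)C=C2`, which departs from compound 2 in one place only: ethyl in place of hydrogen on an amine nitrogen. Going by the values given here, no measured pair isolates this change, so the data give no direct guide to its effect, and any forecast has to stay loose. A small added group makes a moderate rise in the number the most reasonable expectation, meaning somewhat weaker inhibition, though a result within the scatter would be no surprise. The expected step is a 1.9-fold higher number from compound 2 to compound 3 (0.27 log units; within the scatter). For compound 3 the estimated value is 150 nM, with an expected range of 50 nM to 500 nM.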

Compound 3, half-maximal inhibitory concentration: 1030 nM
Compound 3: middle estimate off by 6.9-fold (0.84 log units), on the low side; the measured number lies above the stated range.
By their numbers in this assay, from the lowest: compound 2; then compound 3; then compound 1.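

In this assay, placing ethyl instead of hydrogen on the amine nitrogen gives a 13-fold higher number from compound 2 to compound 3 (1.11 log units; beyond the scatter) and so marks a clear loss of inhibition, well beyond the scatter of repeated measurements. For the compounds shown here, this is the first pair in which only one place in the structure changes, so the loss can be tied directly to the step from amino to ethylamino, and it shows that this nitrogen is not indifferent to what it carries: the form with the added ethyl is the weaker of the two. Nothing measured here bears on the reason for this loss.

With hydrogen and ethyl the only groups shown on this nitrogen, it remains open whether methyl would bring a smaller step, or whether a longer chain such as propyl would weaken inhibition further. As far as these compounds go, it is also open whether a chain carrying a hydroxyl group, or a ring amine such as piperidine in place of the ethylamino group, would bring the number back towards that of compound 2.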